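Benzyloxy moved to a second position on the phenyl ring

This account rests on a few compounds, and the source may have more. Where it says the series, first, only, none or still open, it means among the compounds named here.

Compound 1, with the structure `Cc1nc2cc(-c3ccccc3)nn2c(-c2cc(F)c3c(c2C)CCCO3)c1C(OC(C)(C)C)C(=O)O`, stands highest of the two compounds measured in an ADME assay on microsomes from liver (Homo sapiens), read by LC-MS, using NADPH, with a stated time of 10 min, tested at 0.5 uM (a lower number here means that less of the compound is left, a higher number that more of the compound is left), where compound 1 gives 93%. Its nearest neighbour is compound 2, `Cc1nc2cc(-c3ccc(OCc4ccccc4)cc3)nn2c(-c2cc(F)c3c(c2C)CCCO3)c1C(OC(C)(C)C)C(=O)O`, which in this assay gives 84%; the step of a number 9 percentage points lower from compound 1 to compound 2 (within the scatter) was within the scatter.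

The unmeasured compound 3 has the structure `Cc1nc2cc(-c3cccc(OCc4ccccc4)c3)nn2c(-c2cc(F)c3c(c2C)CCCO3)c1C(OC(C)(C)C)C(=O)O`. Against compound 1 it differs as benzyloxy in place of hydrogen on an aromatic carbon.

Among the compounds with values here, only one measured step bears on this change, the step from compound 1 to compound 2, where benzyloxy also replaced hydrogen on an aromatic carbon; it stayed within the scatter. On that basis no step beyond the scatter is expected in this assay for compound 3, though a small downward shift like that seen for compound 2 is plausible.

Compound 3 is therefore estimated at 85%, between 70% and 96%, which is expected to mean the step of a number 8 percentage points lower from compound 1 to compound 3 (within the scatter).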

Compound 3, percent of the compound remaining: 72%
Compound 3: middle estimate off by 13 percentage points, on the high side, and the stated range covers the measured number.
By their numbers in this assay, from the lowest: compound 3; then compounds 2 and 1 (each within the scatter of the next).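

In this assay, within the data shown here, benzyloxy on an aromatic carbon meta to a large group gives a number 21 percentage points lower from compound 1 to compound 3 (beyond the scatter), the first step here to lie beyond the scatter, whereas the other placement on the phenyl ring gave only a number 9 percentage points lower from compound 1 to compound 2 (within the scatter). This does not separate the two placements from each other, since compound 2 at 84% and compound 3 at 72% stand within the scatter of each other. Nothing available explains the step.

The compounds shown leave open whether a smaller group on the same carbon, such as methoxy or hydroxy, would give a step of similar size. They also leave open whether an amine or a carboxylic acid at the end of a longer chain there would do so.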